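The source may hold more compounds than are shown below. What is called first, only, known or untested is meant among the compounds shown, and "the series" means these compounds.

Going by the values given here, in a functional assay on the whole organism for antagonist activity, with Mus musculus as the target (a lower number here means that less compound is needed, a higher number that more compound is needed for the effect), compound 3 `CSc1nnc(-c2ccccc2F)n1C` gives 61.3 mg/kg, the only actual number among the values so far. Compound 2 `CSc1nnc(-c2ccccc2Cl)n1C` is recorded only as a limit, > 50 mg/kg. Compound 1 `Cn1c(-c2ccccc2)nnc1[S+](C)[O-]`, which carries the group entering here, is also recorded as a limit, > 100 mg/kg. Compound 4 `Cn1c(-c2ccccc2F)nnc1[S+](C)[O-]` differs from compound 3 by a group of 3 heavy atoms (1 carbon, 1 oxygen, 1 sulfur; no ring) in place of a group of 2 heavy atoms (1 carbon, 1 sulfur; no ring), on an aromatic carbon. Among the compounds with values here, the one measured step nearby, a step that the limit leaves unreadable from compound 2 to compound 3, has no readable size and involves a different change, so it gives little guidance. The expectation therefore rests on compound 1 and its limit of > 100 mg/kg, which leans towards more compound being needed in this assay. The expected change, a 1.4-fold higher number from compound 3 to compound 4 (0.14 log units; within the scatter), is small and stays within the usual scatter. Compound 4 is estimated at 85 mg/kg, with an expected range from 30 mg/kg to 220 mg/kg.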

Compound 4, dose for half-maximal effect: 57.9 mg/kg
Compound 4: the middle estimate sits 1.5-fold (0.17 log units) above what was measured; the range from low to high includes it.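

In this assay, exchanging methylsulfanyl for the group of one carbon, one oxygen and one sulfur gives a 1.1-fold lower number from compound 3 to compound 4 (0.02 log units; within the scatter). This change, on the aromatic carbon between two ring nitrogen atoms, therefore leaves the dose needed within the usual scatter. Fluoro in place of hydrogen gives an at least 1.7-fold lower number from compound 1 to compound 4 (0.23 log units; that floor lies within the scatter), and this step is only a floor, as compound 1 is recorded as a limit.

Going by these compounds, the true size of that fluoro step stays open. So does whether an amine or a longer chain on the same carbon would move the dose beyond the scatter.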